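Trifluoromethyl for fluoro beside the amide of compound 2

The source may report more compounds than this note shows. Statements on the series, on what has been measured and on what is new or still open speak of the compounds shown alone.

In an assay on isolated protein for inhibition of Thymidylate synthase (Mus musculus) (a lower number here means a stronger inhibitor, a higher number a weaker inhibitor), compound 2 `C#CCN(Cc1ccc2nc(C)[nH]c(=O)c2c1)c1ccc(C(=O)N[C@@H](CCC(=O)O)C(=O)O)c(F)c1` gives 20 nM, the lowest of the three numbers recorded. Compound 1 `C=CCN(Cc1ccc2nc(C)[nH]c(=O)c2c1)c1ccc(C(=O)N[C@@H](CCC(=O)O)C(=O)O)c(F)c1` gives 76 nM, and the change from compound 1 to compound 2 is a 3.8-fold lower number from compound 1 to compound 2 (0.58 log units; beyond the scatter). Compound 3 `Cc1nc2ccc(CN(CCN)c3ccc(C(=O)N[C@@H](CCC(=O)O)C(=O)O)c(F)c3)cc2c(=O)[nH]1` gives 11700 nM; the step from compound 1 to compound 3 is a 150-fold higher number from compound 1 to compound 3 (2.19 log units; beyond the scatter), and that from compound 2 to compound 3 is a 590-fold higher number from compound 2 to compound 3 (2.77 log units; beyond the scatter). All three measured steps alter the chain on the aromatic nitrogen and leave the benzoyl ring untouched.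

Compound 4 `C#CCN(Cc1ccc2nc(C)[nH]c(=O)c2c1)c1ccc(C(=O)N[C@@H](CCC(=O)O)C(=O)O)c(C(F)(F)F)c1` differs from compound 2 only by trifluoromethyl in place of fluoro on an aromatic carbon. Among the measured compounds shown here, no measured pair changes this position, so none of the three steps bears directly on it. With the chain kept as in compound 2, the change is expected to move this assay only a little, most likely toward a somewhat higher number. Compound 4 is therefore estimated at 45 nM, within 10 nM to 200 nM, a step of a 2.3-fold higher number from compound 2 to compound 4 (0.35 log units; beyond the scatter) from compound 2.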

Compound 4, half-maximal inhibitory concentration: 480 nM
Beside the measured number, compound 4's estimate is 11-fold (1.03 log units) below it; the measured number lies above the stated range.
By their numbers in this assay, from the lowest: compound 2; then compound 1; then compound 4; then compound 3.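

In this assay, among the compounds shown here, trifluoromethyl in place of fluoro gives a 24-fold higher number from compound 2 to compound 4 (1.38 log units; beyond the scatter) and so shows that the aromatic carbon ortho to a (1,3-dicarboxypropyl)carbamoyl group, which no earlier pair had changed, is sensitive to this replacement. The earlier steps shown here all lay in the chain on the aromatic nitrogen, whereas this large step shows that a single change on the benzoyl ring can also move the number well beyond the scatter. Nothing measured here accounts for this step.

On these data alone, how hydrogen, chloro or methyl on this carbon would compare with fluoro and trifluoromethyl remains open. Also open, as far as these compounds go, is whether trifluoromethyl would produce a step of similar size with the chain of compound 1 or compound 3 in place of the chain of compound 2.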